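A few compounds are considered here, and "the series" means these few. Any claim that something is new, unique, unknown or untested is made for them only; others in the source may bear on it.

Measured so far in a functional assay on A549 cells (Homo sapiens) for cytotoxicity, read by MTT assay, with a stated time of 48 h; on this read-out lower numbers stand for stronger inhibition and higher numbers for weaker inhibition:
- compound 1 `COc1cc(/C=C/c2ccc(C)cc2)c(-c2ccccc2)c(OC)c1OC`: 54000 nM
- compound 2 `C=C(c1ccccc1)c1cc(OC)c(OC)c(OC)c1-c1ccccc1`: 17000 nM

Compound 2 holds the lower of the two numbers. Next comes compound 3 `C=C(c1ccc(C)cc1)c1cc(OC)c(OC)c(OC)c1-c1ccccc1`, with the change methyl in place of hydrogen on an aromatic carbon, turning 1-phenylethenyl into 1-(4-methylphenyl)ethenyl. Among the compounds with values here, only one measured step bears on this, a 3.2-fold lower number from compound 1 to compound 2 (0.50 log units; beyond the scatter). Within the data shown here, that step replaces 2-(4-methylphenyl)ethenyl with 1-phenylethenyl, so it does not isolate the methyl, and the data hold no clean methyl step. It gives only a weak hint that the methyl may cost a little in this assay. No shift beyond the scatter is expected, with a slight lean toward a higher number: the estimated step is a 1.3-fold higher number from compound 2 to compound 3 (0.11 log units; within the scatter). For compound 3 the expected value is 22000 nM, with an estimated range of 9000 nM to 52000 nM.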

Compound 3, half-maximal inhibitory concentration: 35000 nM
For compound 3 the middle estimate is 1.6-fold (0.20 log units) below the measured one, and the stated range covers the measured number.
By their numbers in this assay, from the lowest: compound 2; then compounds 3 and 1 (each within the scatter of the next).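

Working notes on the methyl step: in this assay the change gives a 2.1-fold higher number from compound 2 to compound 3 (0.31 log units; beyond the scatter), the first clean read of methyl in place of hydrogen at this position, para to a large group, and it shows that the substitution on the 1-phenylethenyl group is not neutral. With the methyl held constant, 1-(4-methylphenyl)ethenyl in place of 2-(4-methylphenyl)ethenyl gives a 1.5-fold lower number from compound 1 to compound 3 (0.19 log units; within the scatter), which lies within the scatter, so this pair separates no difference between the two ethenyl attachments. No measurement on hand accounts for either step.

Going by these compounds, whether the same position tolerates a methoxy group, a chlorine atom, an amine or a longer chain remains open. Also open, on these data alone, is whether the methyl step would repeat with a plain 2-phenylethenyl group on the shared core.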